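Sulfonyl on the aromatic nitrogen of compound 2

The source may hold more compounds than are shown below. What is called first, only, known or untested is meant among the compounds shown, and "the series" means these compounds.

Three compounds of this series have numbers in a functional assay on 3T3-L1 cells (Mus musculus) for inhibition, with a stated time of 20 min, tested at 20 uM; a higher number here means more inhibition at the concentration tested (going by the name of the read-out), a lower number less inhibition. Compound 1 `Cc1ccc(S(=O)(=O)N(Cc2ccccc2)Cc2cccc(F)c2F)cc1` gives -35.7% in this assay. Compound 3 `Cc1ccc(S(=O)(=O)n2c(CN(Cc3cn(Cc4ccc(F)cc4F)nn3)S(C)(=O)=O)c(C)c3ccccc32)cc1` gives -20.8% in this assay. Compound 2 `Fc1cccc(CNCc2c[nH]c3ccccc23)c1F` gives -1.7% in this assay, the highest of the three: its number lies beyond the scatter above compound 3 and further still above compound 1. Among the compounds with values here, none of the three carries the same change as the one now examined, so no measured step guides the next compound directly.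

Compound 4 `O=S(=O)(c1ccc(F)cc1)n1cc(CNCc2cccc(F)c2F)c2ccccc21` differs from compound 2 in one place: (4-fluorophenyl)sulfonyl in place of hydrogen on an aromatic nitrogen. Both compounds that already bear a sulfonyl group, compound 1 with -35.7% and compound 3 with -20.8%, sit lower than compound 2, and on that basis compound 4 is expected to sit somewhat lower too, with a step of a number 10.3 percentage points lower from compound 2 to compound 4 (beyond the scatter) that may not reach beyond the scatter. For compound 4 the estimate in this assay is -12%, within the range from -35% to 8%.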

Compound 4, a percentage reported as inhibition, at one concentration (the size of the read-out at that concentration, not a potency): 21%
Estimate against measurement, compound 4: 33 percentage points below; measured number outside the range, above it.
By their numbers in this assay, from the lowest: compound 1; then compound 3; then compound 2; then compound 4.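

Placing (4-fluorophenyl)sulfonyl in place of hydrogen on the aromatic nitrogen of compound 2 gives the first one-place step of the series in this assay, a number a number 22.7 percentage points higher from compound 2 to compound 4 (beyond the scatter), so this nitrogen is a position where a change can move the read-out upward, and compound 4 stands at 21%. Within the data shown here, compounds 1 and 3 also carry sulfonyl groups but differ from compound 2 in more than one place, so only this step isolates a sulfonyl group on this nitrogen. No measurement here accounts for the step.

Open, going by these compounds, is whether the 4-fluorophenyl ring or the sulfonyl link carries the step, which plain phenylsulfonyl or methylsulfonyl on the same nitrogen would test. Also open, on these data alone, is whether a benzoyl or acetyl group there would move the read-out in the same direction.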